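The source may report more compounds than this note shows. Statements on the series, on what has been measured and on what is new or still open speak of the compounds shown alone.

Compound 3 `Nc1ccc2cc(NC(=O)CCc3ccc(C(F)(F)F)cc3)ccc2n1` carries an amino group on the shared core and, in a functional assay on HEK293 cells for activation of melanin-concentrating hormone receptor 1 (Rattus norvegicus), read by inositol phosphate accumulation (on this read-out lower numbers stand for an effect already at smaller amounts and higher numbers for an effect only at larger amounts of compound), compound 3 gives 720 nM, the highest number of the three measured. Compound 2 `CC1CCCN1c1ccc2cc(NC(=O)CCc3ccc(C(F)(F)F)cc3)ccc2n1` carries a 2-methylpyrrolidin-1-yl group on the same core and gives 270 nM; compound 1 `O=C(CCc1ccc(C(F)(F)F)cc1)Nc1ccc2nc(N3CCC(NS(=O)(=O)O)C3)ccc2c1` carries a 3-(sulfoamino)pyrrolidin-1-yl group there and gives 50 nM. The step of a 2.7-fold higher number from compound 2 to compound 3 (0.43 log units; beyond the scatter) and the step of a 14-fold higher number from compound 1 to compound 3 (1.16 log units; beyond the scatter) both show that exchanging a pyrrolidine for the bare amine raises the number. Compound 4 `CC(=O)NC1CCN(c2ccc3cc(NC(=O)CCc4ccc(C(F)(F)F)cc4)ccc3n2)C1` runs in the opposite direction: 3-acetamidopyrrolidin-1-yl in place of amino on an aromatic carbon. The entering group shares the five-membered ring with compounds 1 and 2 and a hydrogen-bond donor with compound 1, so the two pyrrolidine-to-amine steps are the ones that bear here. A step of an 8.0-fold lower number from compound 3 to compound 4 (0.90 log units; beyond the scatter) is therefore expected in this assay, of a size between those two measured steps. For compound 4 the estimated value in this assay is 90 nM, with a range from 30 nM to 270 nM.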

Compound 4, half-maximal effective concentration: 440 nM
Beside the measured number, compound 4's estimate is 4.9-fold (0.69 log units) below it, outside the stated range (above it).
By their numbers in this assay, from the lowest: compound 1; then compounds 2, 4 and 3 (each within the scatter of the next, the first and the last beyond it).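

In this assay, a larger group on this aromatic carbon does not by itself set compound 4 apart: a 1.6-fold lower number from compound 3 to compound 4 (0.21 log units; within the scatter) and a 1.6-fold higher number from compound 2 to compound 4 (0.21 log units; within the scatter) both lie within the scatter, despite the added five-membered ring and acetamide. The step that does lie beyond the scatter is on the amine nitrogen of the same pyrrolidine, with acetyl in place of sulfo, an 8.8-fold higher number from compound 1 to compound 4 (0.94 log units; beyond the scatter), so among these compounds the low number of compound 1 goes with the sulfo group, not with the pyrrolidine ring alone. No measurement at hand accounts for this difference.

On these data alone, it remains open whether another group on that nitrogen, such as a methanesulfonyl group or a carboxylic acid on a short chain, would give numbers like that of compound 1. Also open, as far as these compounds go, is where a free amine, carrying neither acetyl nor sulfo, would fall relative to compound 1 and compound 4.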